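The source may report more compounds than this note shows. Statements on the series, on what has been measured and on what is new or still open speak of the compounds shown alone.

Working notes on the series.

Compound 1 `COc1ccc(CNc2nc([SeH])nc3ccccc23)cc1` is the starting point. In a functional assay on CCRF-CEM cells (Homo sapiens) for cytotoxicity, read by MTT assay, with a stated time of 72 h (a lower number here means a stronger inhibitor of growth, a higher number a weaker inhibitor of growth), compound 1 reaches only the limit of the measurement, at > 100000 nM. Compound 2 `C[Se]c1nc(N)c2ccccc2n1` gives 65100 nM in this assay. Compound 3 `COc1ccc(CNc2nc(SC)nc3ncccc23)cc1` also sits at a limit of the measurement in this assay, at > 100000 nM. Among the three numbers, compound 1 stands at the limit of > 100000 nM in this assay, at which 2 of the 3 values shown sit, so no number is known for it, only that it lies beyond the range.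

The step to compound 4 `COc1ccc(CNc2nc(SC)nc3ccccc23)cc1` is a group of 2 heavy atoms (1 carbon, 1 sulfur; no ring) in place of one selenium atom, on an aromatic carbon. Going by the values given here, no step between two measured compounds is available, so the size of this change in this assay cannot be read from a comparison. The values of compound 1 and compound 3 both sit at the limit, and compound 2 gives a weak number; on that basis a step in either direction beyond the scatter is not expected, and compound 4 is expected to end near or beyond the limit. The step from compound 1 to compound 4 is estimated as a step that the limit leaves unreadable from compound 1 to compound 4. For compound 4 in this assay the expected value is 150000 nM, with a range from 50000 nM to 500000 nM.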

Compound 4, concentration for 50% growth inhibition: 93700 nM
Beside the measured number, compound 4's estimate is 1.6-fold (0.20 log units) above it, and the stated range covers the measured number.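

In this assay compound 4, with methylsulfanyl on the aromatic carbon between two ring nitrogen atoms, gives 93700 nM as a number within the measured range, so this position on the shared core can carry a readable value. Putting methylsulfanyl in place of the selenium atom amounts to an at least 1.0-fold lower number from compound 1 to compound 4 (0.02 log units; that floor lies within the scatter) and that floor alone shows no step beyond the scatter. How far the true step reaches stays unread, because compound 1 is held only by a limit: the limit of > 100000 nM in this assay, at which 2 of the 4 values shown sit.

As far as these compounds go, what an amine, a carboxylic acid or a longer chain at this position would give in this assay stays open. Also open, from the compounds shown here alone, is whether any group here can move the number far from the limit.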